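The source may hold more compounds than are shown below. What is called first, only, known or untested is meant among the compounds shown, and "the series" means these compounds.

Compound 2 `N/C(=N\NC(=S)N1CCN(c2ccccn2)CC1)c1ccc(F)cn1` gives 13.4% in a functional assay on MCF7 cells (Homo sapiens) for cytotoxicity, read by MTT assay, with a stated time of 72 h, tested at 1 uM (on this read-out lower numbers stand for less inhibition of growth and higher numbers for more inhibition of growth at the one concentration tested), the highest of the three numbers reported so far, although compound 1 `N/C(=N\NC(=S)N1CCOCC1)c1ccc(F)cn1` lies within the usual scatter of it with 12.4%. Compound 3 `Cc1ccnc(/C(N)=N/NC(=S)N2CCOCC2)c1` stands furthest away with 1.22%, a gap that goes beyond the scatter. Compound 4 `Cc1cccc(/C(N)=N/NC(=S)N2CCN(c3ccccn3)CC2)n1` has not yet been measured in this assay. It differs from compound 2 in one place: 6-methylpyridin-2-yl in place of 5-fluoropyridin-2-yl on a carbon with a double bond to nitrogen. Among the compounds with values here, no step between two measured compounds isolates exactly this change. The pair of compound 1 and compound 3 also differs in the group attached to that carbon, but it differs in other respects as well, so their two values, of which compound 3 shows the lower one, offer only loose guidance. On that basis compound 4 is expected to come out somewhat lower than compound 2, with a step of a number 6.4 percentage points lower from compound 2 to compound 4 (within the scatter) that may well remain within the scatter. The estimate for compound 4 in this assay is 7%, with a range from 0% to 17%; whether the measured number falls near the lower or the upper end remains to be seen.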

Compound 4, percent growth inhibition at one concentration: 8.5%
For compound 4 the middle estimate is 1.5 percentage points below the measured one, and the stated range covers the measured number.
By their numbers in this assay, from the lowest: compounds 3, 4, 1 and 2 (each within the scatter of the next, the first and the last beyond it).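

Within the data shown here, with this step, the change at the carbon with a double bond to nitrogen can be read directly for the first time, rather than inferred from a pair that also differs elsewhere. In this assay, 6-methylpyridin-2-yl in place of 5-fluoropyridin-2-yl gives a number 4.9 percentage points lower from compound 2 to compound 4 (within the scatter), so this position does not separate the two groups at the one concentration tested, and the read-out gives no ground for preferring either of them on compounds that otherwise match. No measurement at hand speaks to why the two groups cannot be told apart here.

From the compounds shown here alone, it remains open whether a different kind of group on that carbon, such as an unsubstituted phenyl ring, a carboxylic acid or a longer alkyl chain, would produce a step beyond the scatter. The compounds shown also leave open whether 6-methylpyridin-2-yl and 5-fluoropyridin-2-yl would stay this close with the rest of the molecule as in compound 1, or at concentrations other than the single one used here.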